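A few compounds are considered here, and "the series" means these few. Any claim that something is new, unique, unknown or untested is made for them only; others in the source may bear on it.

Measured so far:
Compound 1, `O=C(O)c1ccc2c(c1)CC(C(=O)Nc1ccc(-c3cn[nH]c3)cc1)CO2`: in an assay on cells for inhibition of Rho-associated protein kinase 2 (Homo sapiens) (a higher number here means a weaker inhibitor, a lower number a stronger inhibitor), compound 1 gives 751 nM.
Compound 2, `COC(=O)c1ccc2c(c1)CC(C(=O)Nc1ccc(-c3cn[nH]c3)cc1)CO2`: in this assay compound 2 gives 22 nM.

Among these two measured compounds, compound 2 holds the lowest number; its nearest neighbour is compound 1, separated by the step of a 34-fold lower number from compound 1 to compound 2 (1.53 log units; beyond the scatter), which lies well beyond the scatter. Compound 3, `CN(C)C(=O)c1ccc2c(c1)CC(C(=O)Nc1ccc(-c3cn[nH]c3)cc1)CO2`, has not yet been measured. It differs from compound 2 in one place: dimethylamino in place of methoxy on a carbonyl carbon. Among the measured compounds shown here, the only measured step, a 34-fold lower number from compound 1 to compound 2 (1.53 log units; beyond the scatter), also concerns the group on this carbonyl carbon and shows that what sits there can move the number a great deal. For the measured compounds named here, that step, however, exchanged a hydrogen for a methyl on the oxygen, whereas the new change replaces the whole methoxy with a dimethylamino, and no measured pair shows this exact exchange. The best guide is therefore compound 2 itself, with room for a shift in either direction. Compound 3 is expected to land near compound 2, with a step of a 1.8-fold higher number from compound 2 to compound 3 (0.26 log units; within the scatter) in this assay, giving an estimate of 40 nM within a range from 10 nM to 160 nM.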

Compound 3, half-maximal inhibitory concentration: 500 nM
Compound 3: middle estimate off by 13-fold (1.10 log units), on the low side, outside the stated range (above it).
By their numbers in this assay, from the lowest: compound 2; then compounds 3 and 1 (each within the scatter of the next).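

On this carbonyl carbon, the methoxy of compound 2 cannot be swapped for another small group without a large change: in this assay there is a 23-fold higher number from compound 2 to compound 3 (1.36 log units; beyond the scatter) when dimethylamino takes its place, even though the exchange is only from methoxycarbonyl to dimethylcarbamoyl. The hydroxy of compound 1 and the dimethylamino of compound 3 sit level, with a 1.5-fold lower number from compound 1 to compound 3 (0.18 log units; within the scatter) as the step between them, so the first measured step did not simply show that capping the hydroxy is enough, and of these three groups only methoxy gives the low number. Nothing available here explains why the oxygen-linked methyl and the nitrogen-linked pair of methyls part so widely.

The three compounds leave open whether the low number belongs to methoxy alone or extends to longer chains on the same oxygen, such as ethoxy or propoxy. Among the compounds shown here, they also leave open how a plain amino or a methylamino group on this carbonyl carbon would compare, which would show whether any amide here gives a high number or only the one carrying two methyl groups.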